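A Ring in Place of the Nitrooxy Chain End

The source may report more compounds than this note shows. Statements on the series, on what has been measured and on what is new or still open speak of the compounds shown alone.

In a functional assay (aorta) with Rattus norvegicus as the target, in the presence of a further agent that is not named here (on this read-out higher numbers stand for an effect only at larger amounts of compound and lower numbers for an effect already at smaller amounts), compound 1 (`COC(=O)C1=C(C)N=C(C)/C(=C(\O)OC)C1c1cccc([N+](=O)[O-])c1`) gives 3.4 nM and compound 2 (`COC(=O)C1=C(C)N=C(C)/C(=C(/O)OC)C1c1ccccc1OCCO[N+](=O)[O-]`) gives 56 nM. Compound 3 (`COC(=O)C1=C(C)N=C(C)/C(=C(/O)OC)C1c1cccc(OCCO[N+](=O)[O-])c1`) gives 750 nM, the highest of the three numbers and beyond the scatter from both of the others. Of these two, compound 2 lies nearer and compound 1 further away.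

Compound 4 (`COC(=O)C1=C(C)N=C(C)/C(=C(/O)OC)C1c1cccc(OCc2c(C)no[n+]2[O-])c1`) shares its core with compound 3 and differs in one group: a group of 7 heavy atoms (3 carbon, 2 nitrogen, 2 oxygen; one five-membered aromatic ring with 3 hetero atoms) in place of a group of 5 heavy atoms (1 carbon, 1 nitrogen, 3 oxygen; no ring), on a saturated chain carbon bound to an oxygen on an aromatic ring. The new group carries a five-membered aromatic ring with 3 hetero atoms, whereas the group it replaces has no ring. For the measured compounds named here, no measured pair here shows a comparable exchange, so the size of the step cannot be read from the data. The numbers run from compound 1 at 3.4 nM to compound 3 at 750 nM, and this wide spread argues for a broad range. A modest move toward a lower number is expected, an estimated step of a 2.5-fold lower number from compound 3 to compound 4 (0.40 log units; beyond the scatter). The estimate for compound 4 is 300 nM, with an expected range from 50 nM to 1800 nM.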

Compound 4, half-maximal effective concentration: 400 nM
For compound 4 the middle estimate is 1.3-fold (0.12 log units) below the measured one, within the range that was stated.
By their numbers in this assay, from the lowest: compound 1; then compound 2; then compounds 4 and 3 (each within the scatter of the next).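

In this assay, putting the ring-bearing group of compound 4 in place of the (nitrooxy)methyl group, on a saturated chain carbon bound to an oxygen on an aromatic ring, amounts to a 1.9-fold lower number from compound 3 to compound 4 (0.27 log units; within the scatter). This is the first pair shown that differs in one place, and it shows that at this position the open nitrooxy chain end and a five-membered aromatic ring with 3 hetero atoms cannot be told apart on this read-out. Nothing at hand accounts for this result.

On these data alone, whether an amine or a carboxylic acid in the same place would also leave the number within the scatter of compound 3 remains open. As far as these compounds go, it is equally open how the ring-bearing group would fare where compound 2 carries its chain.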